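Hydroxy on the phenyl ring: cytotoxicity in Vero cells

The source may hold more compounds than are shown below. What is called first, only, known or untested is meant among the compounds shown, and "the series" means these compounds.

Measured so far:
- compound 1 `OC1(c2nnc(-c3ccccc3)[nH]2)CCCCC1`: 422 ug/mL
- compound 2 `Oc1ccc(-c2nnc(C3(O)CCCCC3)[nH]2)cc1`: 340 ug/mL
- compound 3 `CC1CC(C)(C)CC(O)(c2nnc(-c3ccccc3)[nH]2)C1`: 383 ug/mL

All three values come from an ADME assay on Vero cells (Chlorocebus sabaeus) for cytotoxicity, read by MTT assay, with a stated time of 72 h; a higher number here means that more compound is tolerated, a lower number that less compound is tolerated. Compound 3 and compound 1 share the same pattern of groups on the phenyl ring but carry different cores; the difference between the two cores is not broken down here, and their values lie within the scatter of each other.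

The change from compound 1 to compound 2, (hydroxy in place of hydrogen on an aromatic carbon), gave a 1.2-fold lower number from compound 1 to compound 2 (0.09 log units; within the scatter). Compound 4 `CC1CC(C)(C)CC(O)(c2nnc(-c3ccc(O)cc3)[nH]2)C1` arises from compound 3 by the same change, (hydroxy in place of hydrogen on an aromatic carbon). Because that earlier step was a 1.2-fold lower number from compound 1 to compound 2 (0.09 log units; within the scatter), the step from compound 3 to compound 4 in this assay is expected to be small as well, about a 1.2-fold lower number from compound 3 to compound 4 (0.06 log units; within the scatter). For compound 4 the estimate is therefore 330 ug/mL, with a likely range from 220 ug/mL to 500 ug/mL.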

Compound 4, half-maximal cytotoxic concentration: 352 ug/mL
Estimate against measurement, compound 4: 1.1-fold (0.03 log units) below; the measured number falls inside the stated range.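

Putting hydroxy in place of hydrogen on an aromatic carbon gave a 1.1-fold lower number from compound 3 to compound 4 (0.04 log units; within the scatter) in this assay. Set beside the earlier step, the change looks the same on both cores: the same change on two cores in this assay, a 1.2-fold lower number (0.09 log units; within the scatter) from compound 1 to compound 2 and a 1.1-fold lower number (0.04 log units; within the scatter) from compound 3 to compound 4, 1.1-fold (0.06 log units) apart, within the scatter of two such steps. This shows that on these two cores the change leaves the tolerated concentration within the normal spread of repeated measurements, but it does not show that the same would hold on any other core, and two such small steps cannot reveal a slight real effect.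

On these data alone, it remains open whether a methoxy group, an amine or a carboxylic acid in the same place would also stay within that spread. Hydroxy at other places on the phenyl ring also remains open.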